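Pyridin-3-yl in Place of 2-Chlorophenyl: an Expected Outcome

The compounds below may be only part of what the source reports. "The series", "measured", "known", "first", "only" and "open" are said of these compounds alone.

Three analogues sharing one core have been tested in a functional assay on ECa-109 cells (Homo sapiens) for antiproliferative activity, read by MTT assay, with a stated time of 72 h; on this read-out higher numbers stand for weaker inhibition and lower numbers for stronger inhibition. Compound 1 `CCCSc1nc(N/N=C(\C)c2ccc(OC)cc2)c2nnn(Cc3ccccc3)c2n1` reports only a limit, > 64000 nM, and this is recorded as the limit of > 64000 nM in this assay, at which 1 of the 3 values shown sits. Compound 2 `CCCSc1nc(N/N=C/c2ccccc2Cl)c2nnn(Cc3ccccc3)c2n1` gives 6180 nM in this assay. Compound 3 `CCCSc1nc(N/N=C/c2cc(OC)c(OC)c(OC)c2)c2nnn(Cc3ccccc3)c2n1` gives 4060 nM in this assay. Among the two numbers that are not limits, compound 2 holds the higher one, but its gap to compound 3 lies within the usual scatter of repeated measurements, so the two cannot be ranked against each other on these data.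

Compound 4 `CCCSc1nc(N/N=C/c2cccnc2)c2nnn(Cc3ccccc3)c2n1` has not yet been measured. It differs from compound 2 in a single place: pyridin-3-yl in place of 2-chlorophenyl on a carbon with a double bond to nitrogen. No measured pair in this set isolates a comparable exchange, so the size of the step has to be judged from the spread of the shown values alone. The author expects the change from compound 2 to compound 4 to be small, a 1.5-fold higher number from compound 2 to compound 4 (0.16 log units; within the scatter), with no strong lean in either direction and a modest tilt toward a weaker result. Compound 4 is therefore estimated at 9000 nM in this assay, within a range from 3000 nM to 40000 nM.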

Compound 4, half-maximal inhibitory concentration: > 64000 nM
Compound 4: only a limit was reported; the forecaster's own chance of this, stated with the estimate: 15%; middle value at least 7.1-fold (0.85 log units) away from the limit.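

Pyridin-3-yl in place of 2-chlorophenyl on a carbon with a double bond to nitrogen is the only single-place exchange in this set, and in this assay it gives an at least 10-fold higher number from compound 2 to compound 4 (1.01 log units; beyond the scatter), so this position is not indifferent to the ring it carries. Compound 4 reports only a limit, > 64000 nM, which means that the step has a lower bound but no measured size. This limit now appears twice among the compounds shown: the limit of > 64000 nM in this assay, at which 2 of the 4 values shown sit.

On these data alone, whether the step goes with the absence of the chlorine or with the presence of the ring nitrogen stays open, since compound 2 and compound 4 differ in both at once. A plain phenyl group on this carbon would separate those two changes, while pyridin-2-yl or pyridin-4-yl would show whether the place of the ring nitrogen matters.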